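From Nitro to Tetrazole: What to Expect for Compound 4

The compounds below may be only part of what the source reports. "The series", "measured", "known", "first", "only" and "open" are said of these compounds alone.

Compound 1, `CCCS(=O)(=O)Nc1ccc(F)c(C(=O)c2n[nH]c3ncc(-c4ccccc4Cl)cc23)c1F`, gives 9.3%.
Compound 2, `CCCS(=O)(=O)Nc1ccc(F)c(C(=O)c2n[nH]c3ncc(-c4ccc(F)cc4)cc23)c1F`, gives 2.1%.
Compound 3, `CCCS(=O)(=O)Nc1ccc(F)c(C(=O)c2n[nH]c3ncc(-c4ccc([N+](=O)[O-])cc4)cc23)c1F`, gives 4.2%.

All three were tested in an assay for binding affinity to dual specificity mitogen-activated protein kinase kinase 4 (Homo sapiens), read by KINOMEscan, tested at 100 nM; on this read-out lower numbers stand for a stronger effect and higher numbers for a weaker effect at the one concentration tested. Compound 3 stands second highest of the three numbers; its nearest neighbour is compound 2, with a number 2.1 percentage points higher from compound 2 to compound 3 (within the scatter), and the furthest is compound 1, with a number 5.1 percentage points lower from compound 1 to compound 3 (within the scatter). Neither gap reaches beyond the scatter, so on these numbers the three compounds cannot be told apart.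

Compound 4, `CCCS(=O)(=O)Nc1ccc(F)c(C(=O)c2n[nH]c3ncc(-c4ccc(-c5nnn[nH]5)cc4)cc23)c1F`, has not yet been measured. It differs from compound 3 in one place: 1H-tetrazol-5-yl in place of nitro on an aromatic carbon. Among the measured compounds shown here, two measured steps bear on this. One is a number 2.1 percentage points higher from compound 2 to compound 3 (within the scatter), an exchange of the group on the same six-membered ring, and the other is a number 7.2 percentage points lower from compound 1 to compound 2 (within the scatter), a change of the whole aryl group; both lay within the scatter. Every exchange on this ring so far has left the read-out unchanged within the scatter, so the expected step of a number 1.3 percentage points higher from compound 3 to compound 4 (within the scatter) is none beyond the scatter. Compound 4 is therefore estimated at 5.5%, with an expected range from 1% to 16%.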

Compound 4, a percentage reported as activity, at one concentration (the size of the read-out at that concentration, not a potency): 0.15%
For compound 4 the middle estimate is 5.4 percentage points above the measured one; the whole stated range lies above it.
By their numbers in this assay, from the lowest: compounds 4, 2, 3 and 1 (each within the scatter of the next).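

In this assay, 1H-tetrazol-5-yl in place of nitro gives a number 4.1 percentage points lower from compound 3 to compound 4 (within the scatter), so at this place, para to a large group, a five-membered aromatic ring with 4 hetero atoms and a hydrogen-bond donor leaves the read-out within the scatter of the nitro compound. The comparisons with the other two compounds read the same way: 1H-tetrazol-5-yl in place of fluoro gives a number 2 percentage points lower from compound 2 to compound 4 (within the scatter), and the whole 4-(1H-tetrazol-5-yl)phenyl group in place of 2-chlorophenyl gives a number 9.2 percentage points lower from compound 1 to compound 4 (within the scatter), so the four compounds cannot be told apart in this assay. A second ring can therefore be added at this place without a step beyond the scatter, but nothing available explains why the read-out holds.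

The compounds shown leave open whether a carboxylic acid or an amine at the same place would also stay within the scatter. Because all four compounds were read at one concentration, they also leave open whether their potencies differ, which a full concentration series could show.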